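Removing the cyclohexyl from the amide nitrogen of compound 1

This account rests on a few compounds, and the source may have more. Where it says the series, first, only, none or still open, it means among the compounds named here.

Compound 1 `O=C1COc2ccc(-c3cnc(Cl)c(NS(=O)(=O)c4ccc(F)cc4)c3)cc2N1C1CCCCC1` gives 37900 nM in a functional assay on A549 cells (Homo sapiens) for antiproliferative activity, read by MTT assay, with a stated time of 72 h (on this read-out higher numbers stand for weaker inhibition and lower numbers for stronger inhibition), the highest of the two numbers recorded; compound 2 `COc1ncc(-c2ccc3c(c2)N(C2CCCCC2)C(=O)CO3)cc1NS(=O)(=O)c1ccc(F)cc1` gives 24600 nM, and the step of a 1.5-fold lower number from compound 1 to compound 2 (0.19 log units; within the scatter) is within the scatter. Compound 3 `O=C1COc2ccc(-c3cnc(Cl)c(NS(=O)(=O)c4ccc(F)cc4)c3)cc2N1` differs from compound 1 by hydrogen in place of cyclohexyl on an amide-type nitrogen in a ring. Among the compounds with values here, no measured step touches that amide nitrogen; the only step recorded concerns the aromatic chloro and is small. Without a guiding step, compound 3 is expected to give a number near compound 1 with a wide range, a 1.3-fold higher number from compound 1 to compound 3 (0.12 log units; within the scatter). Compound 3 is estimated at 50000 nM, between 15000 nM and 200000 nM.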

Compound 3, half-maximal inhibitory concentration: > 40000 nM
Compound 3 was reported as a limit (the forecaster's own chance of this, stated with the estimate: 20%); the middle value does not contradict the limit.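

In this assay compound 3 stands only as a limit, > 40000 nM, not as a number. The step is an at least 1.0-fold higher number from compound 1 to compound 3 (0.02 log units; that floor lies within the scatter), so hydrogen in place of cyclohexyl on this amide-type nitrogen brings no stronger inhibition, and the true size of the change stays unread because the reading ends at a limit: the limit of > 40000 nM in this assay, at which 1 of the 3 values shown sits.

Still open, going by these compounds, is whether a methyl, a longer chain or an amine on this nitrogen would give a readable number. Also open, on these data alone, is whether methoxy in place of chloro would matter with hydrogen on this nitrogen.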